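A few compounds are considered here, and "the series" means these few. Any claim that something is new, unique, unknown or untested is made for them only; others in the source may bear on it.

Going by the values given here, compound 3 (`NC(=O)C1CCN(c2nccnc2OC2CN(c3ccc4ccccc4n3)C2)CC1`) gives 14000 nM in a physicochemical assay for solubility, in phosphate buffer, at pH 7.4 (on this read-out lower numbers stand for lower solubility and higher numbers for higher solubility), and so holds the lower of the two true numbers so far, well under compound 1 (`OCC1CCN(c2nccnc2OC2CN(c3ccc4ccccc4n3)C2)C1`) at 167000 nM in the same read-out. Compound 2 (`c1ccc2nc(N3CC(Oc4nccnc4N4CCCCC4)C3)ccc2c1`) reports only a limit of < 1000 nM in this read-out.

Compound 4 (`OCc1cccc(-c2nccnc2OC2CN(c3ccc4ccccc4n3)C2)c1`) now carries 3-(hydroxymethyl)phenyl in place of 4-carbamoylpiperidin-1-yl on an aromatic carbon, next to the ring nitrogen (3-(hydroxymethyl)phenyl in place of 4-carbamoylpiperidin-1-yl on an aromatic carbon). All three measured steps bear on this change, since each alters the group at this same place, and all are large. The swap of groups gave an at least 160-fold lower number from compound 1 to compound 2 (2.22 log units; beyond the scatter) and also a 12-fold lower number from compound 1 to compound 3 (1.08 log units; beyond the scatter) in turn, while adding carbamoyl gave an at least 14-fold higher number from compound 2 to compound 3 (1.14 log units; beyond the scatter) on its own. None of them places an aromatic ring there, so they guide the size only loosely. Compound 4 gives up the carbamoyl group of compound 3 at 14000 nM, yet it keeps a hydroxymethyl group as compound 1 does at 167000 nM in the same read-out. A lower number beyond the scatter is therefore expected, smaller than the largest of these steps. The expected change is a 4.7-fold lower number from compound 3 to compound 4 (0.67 log units; beyond the scatter) in this assay by this estimate. For compound 4 the estimate is 3000 nM with 600 nM to 15000 nM as the expected range.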

Compound 4, solubility: 29000 nM
Compound 4: middle estimate off by 9.7-fold (0.99 log units), on the low side, and the stated range ends below it.
By their numbers in this assay, from the lowest: compound 3; then compound 4; then compound 1. At a limit, below all of these: compound 2.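

In this assay, going by these compounds alone, the earlier compounds all carry a non-aromatic ring at this aromatic carbon, and this result shows that a carbon-only aromatic ring can stand there with a number above that of 4-carbamoylpiperidin-1-yl: the change gives a 2.1-fold higher number from compound 3 to compound 4 (0.32 log units; beyond the scatter). The shared hydroxymethyl group does not bring 3-(hydroxymethyl)phenyl level with 3-(hydroxymethyl)pyrrolidin-1-yl, since that swap gives a 5.8-fold lower number from compound 1 to compound 4 (0.76 log units; beyond the scatter). Piperidin-1-yl remains the lowest group at this place, with an at least 29-fold higher number from compound 2 to compound 4 (1.46 log units; beyond the scatter), though that comparison rests on compound 2 reporting a limit and not a number: the limit of < 1000 nM in this assay, at which 1 of the 4 values shown sits.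

The compounds shown leave open how much of the number for compound 4 belongs to the phenyl ring and how much to its hydroxymethyl group. An unsubstituted phenyl, or a phenyl bearing an amine or a carboxylic acid in place of the hydroxymethyl, would separate these two parts of the change.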